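The source may report more compounds than this note shows. Statements on the series, on what has been measured and on what is new or still open speak of the compounds shown alone.

Measured so far:
Compound 1 `Cc1cc(-c2ccc(O)cc2)c2ncc(CSCCc3ccccc3)n2c1` gives 20 ug/mL in an ADME assay on HEL cells (Homo sapiens) for cytotoxicity, with a stated time of 3 days; on this read-out lower numbers stand for higher toxicity in this test and higher numbers for lower toxicity in this test.
Compound 2 `COc1cccc(-c2cc(C)c3ncc(CSCCc4ccccc4)n3c2)c1` gives 20 ug/mL in this assay.
Compound 3 `Cc1cc(I)cn2c(CSCCc3ccccc3)cnc12` gives >= 0.8 ug/mL in this assay; this is a limit of the assay, not a number.

Compound 1 stands level with compound 2 at the digits shown, within the scatter. Among the compounds with values here, the only measured step, a step that the limit leaves unreadable from compound 2 to compound 3, stays unreadable because compound 3 sits at the limit of >= 0.8 ug/mL in this assay, at which 1 of the 3 values shown sits. Compound 4 `COc1ccc(-c2cc(C)cn3c(CSCCc4ccccc4)cnc23)cc1` differs from compound 1 by methyl in place of hydrogen on an oxygen on an aromatic ring. No measured step touches this change, and the one step shown gives no size to lean on, so for compound 4 a step of no more than the scatter is expected, no change at the digits printed from compound 1 to compound 4 (within the scatter). Compound 4 is therefore estimated at 20 ug/mL in this assay, with a range from 10 ug/mL to 40 ug/mL.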

Compound 4, minimum cytotoxic concentration: 20 ug/mL
Compound 4: middle estimate and measured number agree at the digits printed; the range from low to high includes it.
By their numbers in this assay, from the lowest: compounds 1, 2 and 4 (each within the scatter of the next).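

In this assay the change from 4-hydroxyphenyl to 4-methoxyphenyl gives no change at the digits printed from compound 1 to compound 4 (within the scatter). Within the data shown here, this is the first readable step: on this oxygen on an aromatic ring, methyl in place of hydrogen leaves the read-out level. Nothing shown gives a reason for this.

As far as these compounds go, whether a longer chain on this oxygen, or an amine or a carboxylic acid in place of the hydroxy, would also leave the read-out level stays open. The step from compound 2 to compound 3 still cannot be read.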